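The source may hold more compounds than are shown below. What is called first, only, known or untested is meant among the compounds shown, and "the series" means these compounds.

Compound 1 `CCCOc1ccc(C(=O)NNc2c(Br)cccc2Br)cc1` gives > 100000 nM (a limit)
Compound 2 `CCCCOc1ccc(C(=O)NNc2c(Br)cccc2Br)cc1` gives > 100000 nM (a limit)
Compound 3 `O=C(NNc1c(Br)cccc1Br)c1ccc(-c2ccccc2)cc1` gives 84100 nM

Going by the values given here, in a toxicity assay on MDCK cells (Canis lupus familiaris) for cytotoxicity, read by CCK-8 assay, with a stated time of 48 h (on this read-out higher numbers stand for lower toxicity in this test and lower numbers for higher toxicity in this test), compound 3 is the only one with an actual number, while the entries for compound 1 and compound 2 are limits of the assay. Compound 4 `Nc1ccc(C(=O)NNc2c(Br)cccc2Br)cc1` carries amino in place of phenyl on an aromatic carbon and keeps the shared core. Two measured steps change the group on that same carbon: an at least 1.1-fold lower number from compound 1 to compound 3 (0.07 log units; that floor lies within the scatter) and an at least 1.1-fold lower number from compound 2 to compound 3 (0.07 log units; that floor lies within the scatter) are both floors set by limits, and neither floor lies beyond the scatter. Among the compounds with values here, no measured compound carries amino there, so this is a cautious guess. The estimated change is a 1.1-fold higher number from compound 3 to compound 4 (0.05 log units; within the scatter) and is expected to stay inside the usual scatter. For compound 4 the estimated value is 95000 nM with an expected range from 40000 nM to 200000 nM and the assay may well report only a limit.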

Compound 4, half-maximal cytotoxic concentration: > 100000 nM
Compound 4: a limit, no number (the forecaster's own chance of this, stated with the estimate: 55%); middle value at least 1.0-fold (0.02 log units) away from the limit.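

In this assay, going by these compounds alone, amino on this aromatic carbon joins propoxy and butoxy in giving only a limit, which leaves phenyl as the one group here with an actual number. Amino in place of phenyl gives an at least 1.1-fold higher number from compound 3 to compound 4 (0.07 log units; that floor lies within the scatter), so even this swap of a large ring for a single nitrogen shows no readable change. The steps to compound 4 from compound 1 and compound 2 cannot be read, and most of the series sits at one ceiling: the limit of > 100000 nM in this assay, at which 3 of the 4 values shown sit.

As far as these compounds go, how far compound 1, compound 2 and compound 4 lie past that limit stays open. So does whether a carboxylic acid or a longer chain on this carbon would give an actual number.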